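The source may report more compounds than this note shows. Statements on the series, on what has been measured and on what is new or still open speak of the compounds shown alone.

Working notes on the series in a functional assay on SMA cells (Homo sapiens) for inhibition, read by MTT assay, with a stated time of 72 h; on this read-out lower numbers stand for stronger inhibition of growth and higher numbers for weaker inhibition of growth. Compound 1 `N#C/C(=C\c1c(F)c(F)c(F)c(F)c1F)C(=O)c1c[nH]c2ccccc12` gives 20000 nM in this assay. Compound 3 `COc1ccc(CNC(=O)/C(C#N)=C/c2ccc(C)cc2)cc1` gives 42000 nM in this assay. Compound 2 `N#C/C(=C\c1ccc[nH]1)C(=O)NCc1ccc(Cl)c(Cl)c1` returns only a limit of the assay, > 50000 nM in this assay, so it stands at the weak end of the numbers shown without an exact figure (the limit of > 50000 nM in this assay, at which 1 of the 3 values shown sits). Compound 4 `N#C/C(=C\c1ccccc1)C(=O)NCc1ccc(Cl)c(Cl)c1` is not yet measured; it differs from compound 2 by phenyl in place of 1H-pyrrol-2-yl on a double-bonded chain carbon bound to a double-bonded chain carbon. Among the compounds with values here, with compound 2 known only as a limit, no measured step tells how this change acts. The nearest measured point carrying a carbon-only ring on that chain carbon is compound 3, whose 42000 nM in this assay also sits at weak inhibition. Compound 4 is therefore expected to stay weak, around 45000 nM in this assay, within 15000 nM to 150000 nM. The expected step is an at least 1.1-fold lower number from compound 2 to compound 4 (0.04 log units; that floor lies within the scatter), at most a small gain not safely beyond the scatter, with a real chance that only a limit is returned again.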

Compound 4, concentration for 50% growth inhibition: 43000 nM
For compound 4 the middle estimate is 1.0-fold (0.02 log units) above the measured one, within the range that was stated.
By their numbers in this assay, from the lowest: compound 1; then compounds 3 and 4 (each within the scatter of the next). At a limit, above all of these: compound 2.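

In this assay, phenyl in place of 1H-pyrrol-2-yl on a double-bonded chain carbon bound to a double-bonded chain carbon gives an at least 1.1-fold lower number from compound 2 to compound 4 (0.06 log units; that floor lies within the scatter). At this position, compound 4 now gives a real figure of 43000 nM, so a carbon-only ring here keeps inhibition weak. The size of the step stays open, and only a floor can be read, because compound 2 is known only as a limit: the limit of > 50000 nM in this assay, at which 1 of the 4 values shown sits.

The compounds shown leave open whether an amine or a carboxylic acid on the phenyl of compound 4 would move the number beyond the scatter.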